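A few compounds are considered here, and "the series" means these few. Any claim that something is new, unique, unknown or untested is made for them only; others in the source may bear on it.

Of the compounds shown here, three built on one shared core have been measured in a functional assay on the whole organism with Rattus norvegicus as the target; a higher number here means that more compound is needed for the effect, a lower number that less compound is needed. Compound 1 `CC(NC1=NS(=O)(=O)c2cc(Cl)ccc2N1)C(C)(C)C` gives 10 uM. Compound 3 `CCC(C)NC1=NS(=O)(=O)c2cc(Cl)ccc2N1`, which carries a different chain on the amine nitrogen, gives 25 uM. Compound 2 `CC(NC1=NS(=O)(=O)c2cnccc2N1)C(C)(C)C`, whose core differs from that of the other two, gives 104 uM and so stands highest of the three numbers: compound 3 lies nearest to it and compound 1 furthest, and both gaps are beyond the usual scatter.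

Compound 4 `CC(C)CNC1=NS(=O)(=O)c2cnccc2N1` has not yet been measured. It differs from compound 2 in a single place: isobutyl in place of 1,2,2-trimethylpropyl on an amine nitrogen. The chain on the amine nitrogen thus becomes smaller, and the branching right at the nitrogen is lost.

Among the measured compounds shown here, only one measured step bears on such a change, a 2.5-fold higher number from compound 1 to compound 3 (0.40 log units; beyond the scatter), where a smaller group likewise replaced a larger one on the chain at the amine nitrogen, though on the other core. That step was modest and raised the number. A modest rise is therefore expected here as well, estimated as a 1.9-fold higher number from compound 2 to compound 4 (0.28 log units; within the scatter). For compound 4 the expected value in this assay is 200 uM, with a range from 80 uM to 500 uM.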

Compound 4, concentration for half-maximal effect: 205 uM
Beside the measured number, compound 4's estimate is 1.0-fold (0.01 log units) below it; the measured number falls inside the stated range.
By their numbers in this assay, from the lowest: compound 1; then compound 3; then compounds 2 and 4 (each within the scatter of the next).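

In this assay, placing isobutyl instead of 1,2,2-trimethylpropyl on the amine nitrogen of this core gives a 2.0-fold higher number from compound 2 to compound 4 (0.29 log units; within the scatter), so on this core the smaller chain cannot be told apart from the larger one by this measurement. The earlier step on the other core, a 2.5-fold higher number from compound 1 to compound 3 (0.40 log units; beyond the scatter), lay beyond the scatter, but it involved a different change of chain, so the two steps do not show whether the core alters the effect of shortening the chain. Nothing available explains why the chain change leaves the number within the scatter here.

From the compounds shown here alone, the effect of isobutyl on the core of compound 1 remains open, and with it any direct comparison of the same chain change on both cores. Also open, going by these compounds, is whether a longer chain, a cyclohexyl ring or a chain ending in a carboxylic acid on the amine nitrogen would move the number beyond the scatter.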